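Iodo in place of hydrogen on the aryl ring

The source may report more compounds than this note shows. Statements on the series, on what has been measured and on what is new or still open speak of the compounds shown alone.

Measured compounds:
compound 1, `Fc1cccc(C2=NCCCC2)c1`: 108 nM
compound 2, `c1ccc(C2=NCCCC2)cc1`: 194 nM

Both compounds share a core that carries a six-membered aromatic ring of carbon only. In an assay on HEK293 cells for displacement of a labelled ligand from Neuronal acetylcholine receptor; alpha3/beta4 (Homo sapiens), read by radioligand binding, with a stated time of 5 min (a higher number here means a weaker inhibitor, a lower number a stronger inhibitor), compound 1 gives 108 nM, and compound 2 gives 194 nM. Among the compounds with values here, compound 2 stands beside compound 1 on these numbers; the single change between them, hydrogen in place of fluoro on an aromatic carbon, produced a 1.8-fold higher number from compound 1 to compound 2 (0.25 log units; within the scatter), so the two cannot be told apart.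

Compound 3, `Ic1cccc(C2=NCCCC2)c1`, has not yet been measured. It differs from compound 2 by iodo in place of hydrogen on an aromatic carbon. Within the data shown here, the only step that bears on this change is the one from fluoro to hydrogen, which stayed within the scatter; iodo is a different halogen, so the comparison is loose. No shift beyond the scatter is expected, and the expected step is a 1.5-fold lower number from compound 2 to compound 3 (0.17 log units; within the scatter). Compound 3 is therefore estimated at 130 nM, with a range from 45 nM to 380 nM.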

Compound 3, inhibition constant: 4.7 nM
Estimate against measurement, compound 3: 28-fold (1.44 log units) above, outside the stated range (below it).
By their numbers in this assay, from the lowest: compound 3; then compounds 1 and 2 (each within the scatter of the next).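

In this assay iodo in place of hydrogen gives a 41-fold lower number from compound 2 to compound 3 (1.62 log units; beyond the scatter) and iodo in place of fluoro gives a 23-fold lower number from compound 1 to compound 3 (1.36 log units; beyond the scatter) and this makes compound 3 the strongest inhibitor of the three. Fluoro and hydrogen could not be told apart at this aromatic carbon, which made the position look insensitive to what it carries, but the new result shows that it responds strongly and that the choice of halogen matters there. Nothing available here explains why iodo differs so much from fluoro and hydrogen. Chloro and bromo at the same carbon would show whether the number falls gradually from fluoro to iodo or only with iodo itself. A methyl or methoxy group there would test whether a halogen is needed at all.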